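From 3-hydroxyphenyl to 4-hydroxyphenyl on the shared core

A few compounds are considered here, and "the series" means these few. Any claim that something is new, unique, unknown or untested is made for them only; others in the source may bear on it.

Among the compounds with values here, in a functional assay on HeLa cells (Homo sapiens) for cytotoxicity, read by ELISA, with a stated time of 2 days (on this read-out higher numbers stand for weaker inhibition and lower numbers for stronger inhibition), compound 1 `Oc1ccccc1-c1cc(-c2ccccc2)nc(-c2ccco2)c1` gives 9700 nM and compound 2 `Oc1cccc(-c2cc(-c3ccccc3)nc(-c3ccco3)c2)c1` gives 10900 nM, so compound 2 stands level with its only neighbour, within the scatter. Compound 3 `Oc1ccc(-c2cc(-c3ccccc3)nc(-c3ccco3)c2)cc1` has not been measured. Its structure differs from that of compound 2 by 4-hydroxyphenyl in place of 3-hydroxyphenyl on an aromatic carbon, with 4-hydroxyphenyl in place of 3-hydroxyphenyl opposite the ring nitrogen. Within the data shown here, the one measured step that bears on this is a 1.1-fold higher number from compound 1 to compound 2 (0.05 log units; within the scatter), which also exchanges one hydroxyphenyl group for another. No change beyond the scatter is therefore expected in this assay. The expected step is a 1.1-fold lower number from compound 2 to compound 3 (0.04 log units; within the scatter). Compound 3 is estimated at 10000 nM, within an expected range of 4500 nM to 22000 nM.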

Compound 3, half-maximal inhibitory concentration: 4500 nM
For compound 3 the middle estimate is 2.2-fold (0.35 log units) above the measured one; the range from low to high includes it.
By their numbers in this assay, from the lowest: compound 3; then compounds 1 and 2 (each within the scatter of the next).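

In this assay this position first responds to the choice of hydroxyphenyl group: 4-hydroxyphenyl in place of 3-hydroxyphenyl gives a 2.4-fold lower number from compound 2 to compound 3 (0.38 log units; beyond the scatter) and 4-hydroxyphenyl in place of 2-hydroxyphenyl gives a 2.2-fold lower number from compound 1 to compound 3 (0.33 log units; beyond the scatter) at the same place. Both steps are modest, yet they set compound 3 apart from compound 1 and compound 2, which stay within the scatter of each other. Nothing given here accounts for this difference.

On these data alone, whether the hydroxyl itself matters remains open, since all three compounds carry one. A 4-methoxyphenyl or 4-aminophenyl group at this place would address that.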